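The source may hold more compounds than are shown below. What is called first, only, known or untested is meant among the compounds shown, and "the series" means these compounds.

Going by the values given here, compound 2 `COc1ccc(CN2CCC(CCNC(=O)/C=C/c3cc(C(C)(C)C)c(O)c(C(C)(C)C)c3)CC2)cc1` is one of two compounds measured in an assay on isolated protein for inhibition of Amine oxidase [flavin-containing] A (Homo sapiens), read by fluorescence, with stated times of 15 min and 20 min; a higher number here means a weaker inhibitor, a lower number a stronger inhibitor. There compound 2 gives 72500 nM, and the other compound, compound 1 `CC(C)(C)c1cc(CCC(=O)NC2CCN(Cc3ccccc3)CC2)cc(C(C)(C)C)c1O`, gives 90200 nM; these two numbers lie within the scatter of each other, so neither stands apart. Compound 3 `CC(C)(C)c1cc(/C=C/C(=O)NCCC2CCN(Cc3cccc(F)c3)CC2)cc(C(C)(C)C)c1O` has not been measured. It differs from compound 2 in one place, (3-fluorophenyl in place of 4-methoxyphenyl on a saturated chain carbon bound to an amine nitrogen in a ring). Among the compounds with values here, no step between measured compounds exists that would show what such a swap does in this assay, and the two measured numbers offer no direction to extrapolate from. The expectation is therefore that the step from compound 2 to compound 3 is a 1.0-fold higher number from compound 2 to compound 3 (0.01 log units; within the scatter), with no movement beyond the scatter in either direction. Compound 3 is accordingly estimated at 75000 nM in this assay, within a range from 25000 nM to 220000 nM.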

Compound 3, half-maximal inhibitory concentration: 58400 nM
Estimate against measurement, compound 3: 1.3-fold (0.11 log units) above; low and high end bracket the measured number.
By their numbers in this assay, from the lowest: compounds 3, 2 and 1 (each within the scatter of the next).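

In this assay, going by these compounds alone, the swap of 4-methoxyphenyl for 3-fluorophenyl on a saturated chain carbon bound to an amine nitrogen in a ring gives the first reading at this position, a 1.2-fold lower number from compound 2 to compound 3 (0.09 log units; within the scatter), and this step lies within the scatter. In this pair, therefore, the assay does not separate 4-methoxybenzyl from 3-fluorobenzyl, although the methoxy oxygen with its hydrogen-bond acceptor leaves and a fluorine enters. No evidence is available on why the step is this size.

Still open, going by these compounds, is whether a ring carrying an amine, a carboxylic acid or a nitrile at this place would move the number beyond the scatter. Also open, on these data alone, is whether the same swap would give a similar step on the core of compound 1.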